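Dithiocarbamate series: pyrrolidinyl versus piperidinyl on the thiocarbonyl

A few compounds are considered here, and "the series" means these few. Any claim that something is new, unique, unknown or untested is made for them only; others in the source may bear on it.

Measured compounds:
- compound 1, `S=C(SCc1nc2ccccc2[nH]1)N1CCCC1`, 1800 nM
- compound 2, `S=C(SCc1nc2ccccc2[nH]1)N1CCCCC1`, 1660 nM
- compound 3, `O=C(CC(SC(=S)N1CCCC1)c1ccccc1)c1ccccc1`, 1670 nM

All three values come from a functional assay on the whole organism for inhibition, with Cicer arietinum as the target, with a stated time of 7 days; on this read-out higher numbers stand for weaker inhibition and lower numbers for stronger inhibition. The three numbers sit close together; compound 2 and compound 3 give nearly the same value, and compound 1 lies a little higher, within the scatter of either.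

The change from compound 1 to compound 2 is piperidin-1-yl in place of pyrrolidin-1-yl on a thiocarbonyl carbon. Its step, a 1.1-fold lower number from compound 1 to compound 2 (0.04 log units; within the scatter), is within the scatter, so on this evidence the ring enlargement leaves the read-out essentially unchanged.

Compound 4, `O=C(CC(SC(=S)N1CCCCC1)c1ccccc1)c1ccccc1`, is not yet measured. It relates to compound 3 as compound 2 relates to compound 1: the change is piperidin-1-yl in place of pyrrolidin-1-yl on a thiocarbonyl carbon. The two place descriptions agree word for word, so this is the same change. How the core of compound 3 differs from the core of compound 1 is not broken down here.

Because the earlier step of a 1.1-fold lower number from compound 1 to compound 2 (0.04 log units; within the scatter) stayed within the scatter, the step from compound 3 to compound 4 is expected to be small as well, about a 1.0-fold lower number from compound 3 to compound 4 (0.02 log units; within the scatter). In this assay compound 4 is therefore estimated at 1600 nM, plausibly between 800 nM and 3300 nM. One precedent is a thin basis; the core of compound 3 might respond differently.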

Compound 4, half-maximal inhibitory concentration: 1850 nM
Beside the measured number, compound 4's estimate is 1.2-fold (0.06 log units) below it; the range from low to high includes it.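

In this assay, piperidin-1-yl in place of pyrrolidin-1-yl on a thiocarbonyl carbon gives a 1.1-fold higher number from compound 3 to compound 4 (0.04 log units; within the scatter), so on the second core too the read-out stays within the scatter. Set side by side, the two steps agree, and the change carries from one core to the other as a step too small to read: the same change on two cores in this assay, a 1.1-fold lower number (0.04 log units; within the scatter) from compound 1 to compound 2 and a 1.1-fold higher number (0.04 log units; within the scatter) from compound 3 to compound 4, 1.2-fold (0.08 log units) apart, within the scatter of two such steps. Going by these compounds alone, this shows only that the exchange of these two rings leaves the number in place on the core of compound 1 and on the core of compound 3; the directions of the two steps carry no meaning, and steps this small cannot show whether a change with a clear effect would carry over in the same way.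

The compounds shown place only pyrrolidin-1-yl and piperidin-1-yl on the thiocarbonyl carbon, so a morpholine ring or an open-chain diethylamino group in that place remains open. From the compounds shown here alone, whether the exchange behaves the same way on any further core also remains open.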